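Carbonyl substituent change on compound 1: carbamate for amide

A few compounds are considered here, and "the series" means these few. Any claim that something is new, unique, unknown or untested is made for them only; others in the source may bear on it.

Measured compounds:
compound 1 `O=C(CC1CCCCCC1)N1CCC(c2nc(-c3ccc4ccccc4n3)no2)CC1` gives 840 nM in a functional assay on Shh Light II cells (Mus musculus) for inhibition, read by a luciferase reporter; a higher number here means a weaker inhibitor, a lower number a stronger inhibitor
compound 2 `Cn1c(-c2noc(C3CCN(C(=O)NC4CCS(=O)(=O)CC4)CC3)n2)nc2ccccc21` gives 350 nM
compound 3 `Cn1c(-c2noc(C3CCN(C(=O)NC4CCCCC4)CC3)n2)nc2ccccc21` gives 89 nM

Compound 1 gives the highest number of the three in this assay, with compound 2 nearest and compound 3 furthest from it; both gaps are beyond the scatter, so compound 1 is the weakest inhibitor measured so far.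

Compound 4 `COc1ccccc1OC(=O)N1CCC(c2nc(-c3ccc4ccccc4n3)no2)CC1` differs from compound 1 in one place: 2-methoxyphenoxy in place of cycloheptylmethyl on a carbonyl carbon. The carbonyl carbon keeps its amide-type ring nitrogen, but the group on its other side changes from a saturated chain-linked ring to an aromatic ring joined through oxygen.

Going by the values given here, the only measured step, a 3.9-fold lower number from compound 2 to compound 3 (0.59 log units; beyond the scatter), concerns a group on an amide-type nitrogen in a urea, not the carbonyl substituent altered here, and its core differs from that of compound 1. It shows that the group beyond the piperidine carbonyl can move the number by a modest amount, but gives no direction for an aromatic ether in place of cycloheptylmethyl. Among the compounds with values here, no measured compound carries an aryl carbamate. The step is therefore expected to be small, a 1.2-fold lower number from compound 1 to compound 4 (0.08 log units; within the scatter), with direction uncertain.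

Compound 4 is expected to give about 700 nM in this assay, within the range 250 nM to 2500 nM.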

Compound 4, half-maximal inhibitory concentration: 250 nM
Beside the measured number, compound 4's estimate is 2.8-fold (0.45 log units) above it; measured number inside the range.
By their numbers in this assay, from the lowest: compound 3; then compounds 4 and 2 (each within the scatter of the next); then compound 1.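

In this assay, going by these compounds alone, 2-methoxyphenoxy in place of cycloheptylmethyl on the carbonyl carbon gives a 3.4-fold lower number from compound 1 to compound 4 (0.53 log units; beyond the scatter), the first measured step at this position on the core of compound 1. The earlier step concerned only a group on an amide-type nitrogen in a urea, whereas this one shows that the group on the carbonyl carbon itself moves the number, and that a seven-membered non-aromatic ring of carbon is not required here: an aromatic ring joined through oxygen gives a stronger inhibitor. No measurement at hand accounts for this gain, which rests on a single pair of compounds.

On these data alone, the change alters the ring, the link and the ring substituent at once, so the share of each in the step stays open; a plain phenoxy or a benzyl group on the same carbonyl carbon would begin to separate them. Also open, as far as these compounds go, is whether the gain carries over to the core of compound 3, which a 2-methoxyphenoxy carbamate on that core would test.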